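A few compounds are considered here, and "the series" means these few. Any claim that something is new, unique, unknown or untested is made for them only; others in the source may bear on it.

Values so far in a functional assay on PC-3 cells (Homo sapiens) for antiproliferative activity, read by CCK-8 assay, with a stated time of 72 h; on this read-out higher numbers stand for weaker inhibition and lower numbers for stronger inhibition
Compound 1 (`Cc1cc(Nc2cc(N3CCN(C)CC3)nc(Nc3ccc(S(N)(=O)=O)cc3)n2)n[nH]1`): 4380 nM
Compound 2 (`Cc1cc(Nc2cc(N3CCN(C)CC3)nc(Nc3ccc(Cl)cc3)n2)n[nH]1`): 1480 nM
Compound 3 (`Cc1cc(Nc2cc(N3CCN(C)CC3)nc(Nc3cccc([N+](=O)[O-])c3)n2)n[nH]1`): 962 nM

Compound 3 cannot be separated from its nearest neighbour (a 1.5-fold lower number from compound 2 to compound 3 (0.19 log units; within the scatter)) but stands clear of the sulfamoyl compound (a 4.6-fold lower number from compound 1 to compound 3 (0.66 log units; beyond the scatter)). The next compound is compound 4 (`Cc1cc(Nc2cc(N3CCN(C)CC3)nc(Nc3cccc(Cl)c3)n2)n[nH]1`), which has chloro in place of nitro on an aromatic carbon. Within the data shown here, no measured pair makes this exchange at a single place on the ring, so the closest evidence is the comparison of chloro-bearing compound 2 with nitro-bearing compound 3, whose step stays inside the scatter. The modest step away from compound 1 (a 3.0-fold lower number from compound 1 to compound 2 (0.47 log units; beyond the scatter)) concerns loss of the sulfamoyl group, which neither compound 3 nor compound 4 carries, and it bears only weakly here. No step beyond the scatter is therefore expected in this assay, and the estimated change is small (a 1.2-fold higher number from compound 3 to compound 4 (0.10 log units; within the scatter)). Compound 4 is estimated at 1200 nM (expected range 520 nM to 2800 nM).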

Compound 4, half-maximal inhibitory concentration: 573 nM
Estimate against measurement, compound 4: 2.1-fold (0.32 log units) above; the measured number falls inside the stated range.
By their numbers in this assay, from the lowest: compounds 4, 3 and 2 (each within the scatter of the next, the first and the last beyond it); then compound 1.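

In this assay, the exchange of nitro for chloro at one ring place is now read directly, and it stays within the scatter (a 1.7-fold lower number from compound 3 to compound 4 (0.23 log units; within the scatter)), so these two groups are not separated at this place. Among these compounds, the shift from 4-chlorophenyl to 3-chlorophenyl gives the first clean comparison of ring place with the group held constant, and it lies beyond the scatter (a 2.6-fold lower number from compound 2 to compound 4 (0.41 log units; beyond the scatter)), while the gap to the sulfamoyl compound widens (a 7.6-fold lower number from compound 1 to compound 4 (0.88 log units; beyond the scatter)). No measurement shown accounts for these steps.

Going by these compounds, whether the preference for 3-chlorophenyl over 4-chlorophenyl extends to other groups remains open, since nitro and sulfamoyl each appear at one ring place only. On these data alone, how an amine or a carboxylic acid would behave at the place held by chloro also remains open.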